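A few compounds are considered here, and "the series" means these few. Any claim that something is new, unique, unknown or untested is made for them only; others in the source may bear on it.

Compound 1 `CCCSc1nnc(COc2cc(C)c3c(C)cc(=O)oc3c2)o1` and compound 2 `Cc1cc(OCc2nnc(SCc3ccc(F)c(F)c3)o2)cc2oc(=O)cc(C)c12` share one core and were both tested in a functional assay on MDA-MB-231 cells (Homo sapiens) for antiproliferative activity, read by MTT assay, with a stated time of 24 h; a lower number here means a stronger inhibitor, a higher number a weaker inhibitor. Compound 1 gives only the limit of > 100000 nM. Compound 2 likewise gives only the limit of > 100000 nM. The step that the two limits leave unreadable from compound 1 to compound 2 is therefore unreadable, since both values sit at the limit of > 100000 nM in this assay, at which 2 of the 2 values shown sit. Compound 3 `Cc1cc(OCc2nnc(S(=O)(=O)Cc3ccccc3)o2)cc2oc(=O)cc(C)c12` differs from compound 2 by benzylsulfonyl in place of (3,4-difluorobenzyl)sulfanyl on an aromatic carbon. Within the data shown here, no measured step bears on this change, and the single recorded step has no readable size, so no direction can be drawn. Compound 3 is expected to remain at the limit as well, with an estimated value of 150000 nM, between 40000 nM and 600000 nM, which would mean a step that the limit leaves unreadable from compound 2 to compound 3.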

Compound 3, half-maximal inhibitory concentration: 7070 nM
Compound 3: middle estimate off by 21-fold (1.33 log units), on the high side; measured number outside the range, below it.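

In this assay, among these compounds, benzylsulfonyl on this aromatic carbon gives the first readable number, with an at least 14-fold lower number from compound 2 to compound 3 (1.15 log units; beyond the scatter) and an at least 14-fold lower number from compound 1 to compound 3 (1.15 log units; beyond the scatter). Among the compounds shown here, the position can therefore respond to the group it carries, which the earlier compounds could not show. Both sulfanyl compounds give only a limit, not a number: the limit of > 100000 nM in this assay, at which 2 of the 3 values shown sit.

The change from compound 2 to compound 3 both brings in the sulfonyl and removes the two fluorines, and the compounds shown do not separate these. Also open, going by these compounds, is how a (3,4-difluorobenzyl)sulfonyl, a propylsulfonyl or an amine at this position would read.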